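A few compounds are considered here, and "the series" means these few. Any claim that something is new, unique, unknown or untested is made for them only; others in the source may bear on it.

Measured compounds in a functional assay on the whole organism for inhibition, with Mus musculus as the target, with a stated time of 1 h, at a dose of 30 mg/kg by the intraperitoneal route; a higher number here means more inhibition at the dose given (going by the name of the read-out), a lower number less inhibition:
- compound 1 `O=C(/C=C/C1=Cc2ccccc2OC1)c1ccc(Cl)cc1` gives 56.1%
- compound 2 `O=C(/C=C/C1=Cc2ccccc2OC1)c1ccccc1Br` gives 56.6%
- compound 3 `COc1ccc(C(=O)/C=C/C2=Cc3ccccc3OC2)cc1` gives 66.2%

Compound 2 stands second highest of the three numbers in this assay. Its nearest neighbour is compound 1, whose number lies within the scatter of it, and its furthest is compound 3, whose number also lies within the scatter of it, so no order among the three can be read from compound 2 alone.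

Compound 4 `Nc1ccc(C(=O)/C=C/C2=Cc3ccccc3OC2)cc1` is not yet measured. It differs from compound 2 in one place: 4-aminophenyl in place of 2-bromophenyl on a carbonyl carbon.

For the measured compounds named here, two measured steps bear on this change, both on the aryl group attached to the carbonyl carbon. The step of a number 0.5 percentage points higher from compound 1 to compound 2 (within the scatter), which swaps one halogenated phenyl for another, did not move the number. The step of a number 10.1 percentage points higher from compound 1 to compound 3 (beyond the scatter), methoxy in place of chloro, gave the only shift beyond the scatter in the series, and a modest one. Compound 4 brings yet another substituted phenyl to the same carbonyl carbon, so a step of similar size is expected, and in the upward direction, because compound 3 66.2% sits highest among the measured values.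

Compound 4 is therefore estimated at 64% in this assay, within 50% to 78%, meaning an expected step of a number 7.4 percentage points higher from compound 2 to compound 4 (within the scatter).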

Compound 4, a percentage reported as inhibition, in the whole organism at one dose (the size of the read-out at that dose, not a potency): 52.6%
For compound 4 the middle estimate is 11.4 percentage points above the measured one; the measured number falls inside the stated range.
By their numbers in this assay, from the lowest: compounds 4, 1, 2 and 3 (each within the scatter of the next, the first and the last beyond it).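

In this assay the step of a number 13.6 percentage points lower from compound 3 to compound 4 (beyond the scatter) marks amino and methoxy on an aromatic carbon of this aryl group as not interchangeable, so the earlier shift with methoxy does not extend to amino. The steps of a number 4 percentage points lower from compound 2 to compound 4 (within the scatter) and a number 3.5 percentage points lower from compound 1 to compound 4 (within the scatter) leave compound 4 indistinguishable from either halogenated compound, and the hydrogen-bond donor and acceptor counted for 4-aminophenyl, absent from 2-bromophenyl, come with no readable change on this carbonyl carbon. No independent measurement bears on what separates the methoxy and amino compounds.

Open, from the compounds shown here alone, is whether a 4-hydroxyphenyl or a 4-(dimethylamino)phenyl on the same carbonyl carbon would read with compound 3 or with compound 4, which would show how narrowly the methoxy result is tied to that one group. The read-out also comes from a single dose and a single time, so these compounds say nothing about how the inhibition changes with dose or how long it lasts.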